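From nitro to 4-butylcyclohexyl: an expected cytotoxicity step

The compounds below may be only part of what the source reports. "The series", "measured", "known", "first", "only" and "open" are said of these compounds alone.

Compound 1 `FC(F)(F)c1cccc(NC(=S)Nc2ccc(I)cc2)c1`: 9400 nM
Compound 2 `O=[N+]([O-])c1ccc(NC(=S)Nc2cccc(C(F)(F)F)c2)cc1`: 9500 nM

Both values were measured in an ADME assay on BHK cells (Mesocricetus auratus) for cytotoxicity, read by MTT assay, with a stated time of 96 h; on this read-out higher numbers stand for lower toxicity in this test and lower numbers for higher toxicity in this test. Compound 2 gives 9500 nM, which lies within the scatter of compound 1 at 9400 nM, so neither compound stands apart from the other. Compound 3 `CCCC[C@H]1CC[C@H](c2ccc(NC(=S)Nc3cccc(C(F)(F)F)c3)cc2)CC1` has not yet been measured. It carries 4-butylcyclohexyl in place of nitro on an aromatic carbon. Among the measured compounds shown here, only one measured step bears on this change, the exchange of iodo for nitro on an aromatic carbon. For the measured compounds named here, with a 1.0-fold higher number from compound 1 to compound 2 (0.00 log units; within the scatter) as the only evidence, no step beyond the scatter is expected in this assay, and no direction is favoured. Neither measured compound carries a non-aromatic ring, and the range is kept wide. The expected step is a 1.1-fold lower number from compound 2 to compound 3 (0.02 log units; within the scatter). Compound 3 is estimated at 9000 nM, with an expected range of 3000 nM to 27000 nM.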

Compound 3, half-maximal cytotoxic concentration: 9500 nM
Compound 3: middle estimate off by 1.1-fold (0.02 log units), on the low side; the measured number falls inside the stated range.
By their numbers in this assay, from the lowest: compounds 1, 2 and 3 (each within the scatter of the next).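

In this assay, replacing nitro with 4-butylcyclohexyl gives no change at the digits printed from compound 2 to compound 3 (within the scatter), while replacing iodo with the same group gives a 1.0-fold higher number from compound 1 to compound 3 (0.00 log units; within the scatter). This place on the aromatic ring, para to a large group, thus carries a group of 10 heavy atoms, all carbon, with a six-membered non-aromatic ring and 2 defined stereocentres, and the number still lies within the scatter of those for the iodo and nitro compounds, which those two groups alone could not show. No measurement here accounts for the three numbers lying so close together.

On these data alone, whether an amine or a carboxylic acid at this place would give a number beyond the scatter remains open. Also open, as far as these compounds go, is whether a longer chain on the cyclohexyl ring would do so.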